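Removing a methyl from an ethoxy group on the core

The compounds below may be only part of what the source reports. "The series", "measured", "known", "first", "only" and "open" are said of these compounds alone.

Compound 1, with structure `CCO/N=C1\C(=O)N(CCCCOc2ccc3oc(-c4ccc(OC)cc4)c(C(=O)OCC)c3c2)c2ccc(F)cc21`, compound 2, with structure `CCOC(=O)c1c(-c2ccc(OC)cc2)oc2ccc(OCCCCN3C(=O)/C(=N\OC)c4cc(F)ccc43)cc12`, and compound 3, with structure `CCO/N=C1\C(=O)N(CCCCOc2ccc3oc(-c4ccc(OC)cc4)c(C(=O)OCC)c3c2)c2ccccc21`, were tested in an ADME assay on Vero cells (Chlorocebus sabaeus) for cytotoxicity, read by MTT assay, with a stated time of 72 h; a lower number here means that less compound is tolerated, a higher number that more compound is tolerated. In that assay compound 1 gives 32 ug/mL, compound 2 gives 32 ug/mL, and compound 3 gives 64 ug/mL. Of the three numbers, that of compound 3 is the one at the top, yet its gaps to compound 1 and to compound 2 are both within the scatter, so the three compounds are tolerated to a similar degree.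

Compound 4, with structure `CCOC(=O)c1c(-c2ccc(OC)cc2)oc2ccc(OCCCCN3C(=O)/C(=N\OC)c4ccccc43)cc12`, has not yet been measured. It differs from compound 3 by hydrogen in place of methyl on a saturated chain carbon bound to an oxygen on an unsaturated carbon. The same kind of change has been seen once already: the step of no change at the digits printed from compound 1 to compound 2 (within the scatter) left the number unchanged within the scatter. The step of a 2.0-fold higher number from compound 1 to compound 3 (0.30 log units; within the scatter), a different change, also stayed within the scatter. Therefore no step beyond the scatter is expected in this assay, which is the estimated meaning of no change at the digits printed from compound 3 to compound 4 (within the scatter). Compound 4 is expected to give about 64 ug/mL, estimated to lie between 32 ug/mL and 128 ug/mL.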

Compound 4, half-maximal cytotoxic concentration: 32 ug/mL
Compound 4: the middle estimate sits 2.0-fold (0.30 log units) above what was measured; low and high end bracket the measured number.
By their numbers in this assay, from the lowest: compounds 1, 2, 4 and 3 (each within the scatter of the next).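

With compound 4, the change from ethoxy to methoxy has a second reading in this assay, this time on the core without the fluoro, and a 2.0-fold lower number from compound 3 to compound 4 (0.30 log units; within the scatter) agrees with the first reading: the same change on two cores in this assay, no change at the digits printed (within the scatter) from compound 1 to compound 2 and a 2.0-fold lower number (0.30 log units; within the scatter) from compound 3 to compound 4, 2.0-fold (0.30 log units) apart, within the scatter of two such steps. The change from fluoro to hydrogen also gains a second reading, no change at the digits printed from compound 2 to compound 4 (within the scatter), now with methoxy in place of ethoxy, and it agrees with its first reading as well: the same change on two cores in this assay, a 2.0-fold higher number (0.30 log units; within the scatter) from compound 1 to compound 3 and no change at the digits printed (within the scatter) from compound 2 to compound 4, 2.0-fold (0.30 log units) apart, within the scatter of two such steps. Across these four compounds, then, neither change moves the number beyond the scatter, whichever group sits at the other place.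

The compounds shown leave open whether a longer chain, or one ending in an amine, would give a step beyond the scatter at this place. They also leave open how a chloro group or a carboxylic acid in place of the fluoro would read.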